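A few compounds are considered here, and "the series" means these few. Any claim that something is new, unique, unknown or untested is made for them only; others in the source may bear on it.

Compound 2 `CCCCNc1nc(N)nc2ccn(Cc3ccccn3)c12` has been measured in an ADME assay on HEK293 cells (Homo sapiens) for cytotoxicity, read by ATP content, with a stated time of 6 h; on this read-out higher numbers stand for lower toxicity in this test and lower numbers for higher toxicity in this test. In this assay compound 2 gives > 24000 nM, which is a limit of the assay and not a number. Compound 1 `CCCCNc1nc(N)nc2ccn(Cc3ccsc3)c12` gives > 24000 nM, and this too is a limit. Among the compounds with values here, the one measured step, a step that the two limits leave unreadable from compound 1 to compound 2, therefore offers no size to build on, and it concerns a different group from the one that changes next.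

Compound 3 `COCCNc1nc(N)nc2ccn(Cc3ccccn3)c12` keeps the pyridin-2-yl group of compound 2 and alters the chain on the amine: methoxy in place of ethyl on a saturated chain carbon, two bonds along the chain from a nitrogen on an aromatic ring. Put another way, butylamino gives way to (2-methoxyethyl)amino. Within the data shown here, no measured step touches this chain, so the comparison rests on little. No step beyond the usual scatter is expected in this assay because the limit of > 24000 nM in this assay, at which 2 of the 2 values shown sit, is all that the two measured compounds show, and another limit is the likeliest report. The estimated change is a step that the limit leaves unreadable from compound 2 to compound 3. For compound 3 the expected value is 30000 nM, with an estimated range from 15000 nM to 60000 nM.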

Compound 3, half-maximal cytotoxic concentration: > 24000 nM
Compound 3: a limit, no number; the forecaster's own chance of this, stated with the estimate: 85%; the middle value lies beyond the limit too.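

Compound 2 and compound 3 both give a limit of the assay and not a number, so no size can be read for the step between them, and the same holds for compound 1: the limit of > 24000 nM in this assay, at which 3 of the 3 values shown sit.

The compounds shown leave open how toxic any of them is to these cells at higher concentrations, and whether butylamino and (2-methoxyethyl)amino differ at all in this test.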